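The source may hold more compounds than are shown below. What is called first, only, known or untested is meant among the compounds shown, and "the series" means these compounds.

Two diterpenoid-type compounds have been tested so far, both carrying the same shared core with a hydroxymethyl and a ring hydroxyl. Compound 1, `C=C1[C@H](O)C[C@@H]2[C@](C)(CO)[C@H](O)CC[C@@]2(C)[C@@H]1CCC1=CCOC1=O`, carries an unsaturated lactone on its side chain. In a functional assay on HL-60 cells (Homo sapiens) for antiproliferative activity, read by trypan blue exclusion (a higher number here means a weaker inhibitor of growth, a lower number a stronger inhibitor of growth), compound 1 gives 22500 nM. Compound 2, `C=C1CC[C@@H]2[C@](C)(CO)[C@H](O)CC[C@@]2(C)[C@@H]1C[C@H](O)[C@@H]1C(=O)OC[C@H]1O`, carries instead a saturated lactone bearing a hydroxyl on the side chain. In this assay compound 2 gives 24400 nM, and this number and that of compound 1 lie within the scatter of each other, so the two cannot be told apart on these data.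

Compound 3, `C=C1CC[C@@H]2[C@](C)(CO)[C@H](O)CC[C@@]2(C)[C@@H]1C[C@@H](O)[C@H]1C(=O)OC[C@H]1O`, is the next compound to be measured. Compared with compound 2, (the two compounds have the same atoms and bonds and differ only in configuration as drawn: 2 of 8 stereo elements differ; a stereocentre at a saturated chain carbon is drawn S in compound 2 and R in compound 3; a stereocentre at a saturated ring carbon is drawn S in compound 2 and R in compound 3). No step between measured compounds bears on such a change in configuration, so there is no shown basis for expecting a move in one direction or the other. The reasonable expectation is therefore no step beyond the scatter, with the estimate for the change from compound 2 to compound 3 being a 1.0-fold lower number from compound 2 to compound 3 (0.01 log units; within the scatter). Compound 3 is expected to give about 24000 nM in this assay, with a range from 8000 nM to 70000 nM.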

Compound 3, concentration for 50% growth inhibition: 26600 nM
Beside the measured number, compound 3's estimate is 1.1-fold (0.04 log units) below it, within the range that was stated.
By their numbers in this assay, from the lowest: compounds 1, 2 and 3 (each within the scatter of the next).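

In this assay, inverting the two stereocentres, one at a saturated chain carbon and one at a saturated ring carbon, gives a 1.1-fold higher number from compound 2 to compound 3 (0.04 log units; within the scatter), so on these data this change in configuration does not separate the two compounds. Among these compounds, compound 1 and compound 2 differ in more than one place and offer no such one-place comparison, which makes this the first direct reading of how far the side chain and its lactone tolerate a change in configuration in this assay. The pair tests configuration alone, with no group gained or lost, because of a simple structural point: the fact that compounds 2 and 3 differ only in the configuration as drawn

Going by these compounds, the two stereocentres differ together in this pair, so the effect of inverting either one alone remains unknown, and two effects that happen to cancel cannot be told from no effect at either centre. On these data alone, it also remains open whether an amine in place of the side-chain hydroxyl, or a carboxylic acid in place of the lactone, would shift the number in this assay beyond the scatter.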